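The compounds below may be only part of what the source reports. "The series", "measured", "known", "first", "only" and "open" are said of these compounds alone.

Measured compounds:
compound 1, `COc1nc(N2CCN(C)CC2)ccc1Sc1cccc(NC(=O)c2ccccc2)c1`, 4700 nM
compound 2, `COc1nc(N2CCN(C)CC2)ccc1Sc1cccc(NC(=O)CN)c1`, 19100 nM
compound 3, `CN1CCN(c2ncc(Sc3cccc(NC(=O)c4ccccc4)c3)c(OCc3ccccc3)n2)CC1`, 3100 nM

The three measured compounds were tested in a functional assay on Kasumi 1 cells (Homo sapiens) for cytotoxicity, read by resazurin assay, with a stated time of 72 h; on this read-out lower numbers stand for stronger inhibition and higher numbers for weaker inhibition. Compound 1 and compound 2 share one core, and they differ in a single place: aminomethyl in place of phenyl on a carbonyl carbon. This change gave a 4.1-fold higher number from compound 1 to compound 2 (0.61 log units; beyond the scatter). Compound 3 is built on a different core; the difference between the two cores is not broken down here. In this assay compound 3 gives 3100 nM, which is close to the value of compound 1 and well apart from that of compound 2.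

Compound 4, `CN1CCN(c2ncc(Sc3cccc(NC(=O)CN)c3)c(OCc3ccccc3)n2)CC1`, has not yet been measured. It stands to compound 3 as compound 2 stands to compound 1: aminomethyl in place of phenyl on a carbonyl carbon. The place of the change is described in the same words for both pairs, so this is the same change made on the second core. For the measured compounds named here, the only direct precedent for it is the step from compound 1 to compound 2, which lies beyond the scatter, and there is no information on how the second core responds to it. The expectation therefore rests on that one step alone. Compound 4 is expected to show a 3.9-fold higher number from compound 3 to compound 4 (0.59 log units; beyond the scatter) in this assay, because the same change gave a 4.1-fold higher number from compound 1 to compound 2 (0.61 log units; beyond the scatter). Compound 4 is thus estimated at 12000 nM, with a likely range from 6000 nM to 25000 nM.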

Compound 4, half-maximal inhibitory concentration: 2300 nM
The estimate for compound 4 lay 5.2-fold (0.72 log units) above the measured number; the whole stated range lies above it.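

In this assay, for the compounds shown here, aminomethyl in place of phenyl on a carbonyl carbon gave a 1.3-fold lower number from compound 3 to compound 4 (0.13 log units; within the scatter), so on the core of compound 3 the change produced no step that stands out from the scatter. The change therefore did not carry over with the same size from the core of compound 1 to the core of compound 3: the same change on two cores in this assay, a 4.1-fold higher number (0.61 log units; beyond the scatter) from compound 1 to compound 2 and a 1.3-fold lower number (0.13 log units; within the scatter) from compound 3 to compound 4, 5.5-fold (0.74 log units) apart, beyond the scatter of two such steps. This shows that, for these two pairs, the effect of the change on the number differs with the core, and that a step seen on one core was not a reliable guide to the other, but two pairs do not show which part of the cores separates them or how the change would behave on any further core.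

The compounds shown leave open which of the features that separate the two cores accounts for the difference, since no compound here carries only part of that difference. They also leave open whether a longer chain ending in an amine, or a carboxylic acid in place of aminomethyl, would likewise give different steps on the two cores.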